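The compounds below may be only part of what the source reports. "The series", "measured", "known", "first", "only" and "open" are said of these compounds alone.

Working notes on the series, read in a functional assay on A549 cells (Homo sapiens) for inhibition, read by MTT assay, with a stated time of 48 h; on this read-out higher numbers stand for weaker inhibition and lower numbers for stronger inhibition. Compound 3 `COc1ccc(N(C)c2nc(C)nc3ccccc23)cc1` lacks any selenium-bearing chain and gives the lowest of the three measured numbers, at 3 nM. Compound 2 `COc1ccc(N(C)c2nc(C)nc3ccccc23)cc1OCC[Se]C#N` comes next at 13 nM, and compound 1 `COc1ccc(N(C)c2nc(C)nc3ccccc23)cc1OCCCCCC[Se]C#N` lies far higher at 5520 nM.

Compound 4 `COc1ccc(N(C)c2nc(C)nc3ccccc23)cc1C[Se]C#N` departs from compound 3 as follows: a group of 4 heavy atoms (2 carbon, 1 nitrogen, 1 selenium; no ring) in place of a hydrogen atom, on an aromatic carbon. The place is ortho to a methoxy group and meta to a large group.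

Among the measured compounds shown here, three measured steps bear on this change. The short-chain comparison is a 4.3-fold lower number from compound 2 to compound 3 (0.64 log units; beyond the scatter), which is modest. The long-chain comparison is a 1800-fold lower number from compound 1 to compound 3 (3.26 log units; beyond the scatter), which is large, and the chain comparison itself is a 420-fold lower number from compound 1 to compound 2 (2.63 log units; beyond the scatter), also large. Across these two chains, the shorter one lies much closer to compound 3. For the measured compounds named here, the group in compound 4 is shorter still and has no oxygen link, and no measured compound carries it, so its effect has not been seen directly.

Compound 2 is the nearest guide, so a modest rise in the number is expected in this assay, with a wide margin. The expected move is a 6.7-fold higher number from compound 3 to compound 4 (0.82 log units; beyond the scatter). For compound 4 the estimated value is 20 nM, with an expected range of 4 nM to 150 nM.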

Compound 4, half-maximal inhibitory concentration: 98 nM
Compound 4: middle estimate off by 4.9-fold (0.69 log units), on the low side, and the stated range covers the measured number.
By their numbers in this assay, from the lowest: compound 3; then compound 2; then compound 4; then compound 1.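

In this assay, the group of 4 heavy atoms on the aromatic carbon ortho to a methoxy group costs more than the short oxygen-linked chain did, with a 33-fold higher number from compound 3 to compound 4 (1.51 log units; beyond the scatter) and a 7.5-fold higher number from compound 2 to compound 4 (0.88 log units; beyond the scatter) as well, so the number does not simply follow group size: compound 4 carries a smaller group than compound 2 yet reads higher, and this goes against any trend drawn from compound 2 and compound 1 alone. The long chain remains the costliest of the changes seen here, with a 56-fold lower number from compound 1 to compound 4 (1.75 log units; beyond the scatter) in the shared core. No measured data on hand account for why the smaller group without the oxygen link reads higher than compound 2.

Going by these compounds, compound 2 and compound 4 differ in both the oxygen link and the chain length, so the contribution of each stays open, and an oxygen-linked chain intermediate in length would show where the steep climb towards compound 1 begins. Equally open, on these data alone, is what the selenium itself contributes, which a sulfur atom in its place or a simple nitrile on the same aromatic carbon would help to separate from the effect of the chain.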